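Purine glycinamide esters: side chain swap toward compound 4

The source may hold more compounds than are shown below. What is called first, only, known or untested is meant among the compounds shown, and "the series" means these compounds.

Compound 1 `O=C(CN(c1nc(Cl)nc2[nH]cnc12)C1CC1)N[C@@H](CO)C(=O)OCc1ccccc1`: 27.9%
Compound 2 `C[C@@H](O)[C@H](NC(=O)CN(c1nc(Cl)nc2[nH]cnc12)C1CC1)C(=O)OCc1ccccc1`: 12.8%
Compound 3 `CC(C)C[C@H](NC(=O)CN(c1nc(Cl)nc2[nH]cnc12)C1CC1)C(=O)OCc1ccccc1`: 5.26%

In a functional assay on the whole organism (Tail, strain ICR) with Mus musculus as the target, in the tail flick test, with a stated time of 150 min, at a dose of 25 umol/kg by the oral route (on this read-out lower numbers stand for a weaker effect and higher numbers for a stronger effect at the one dose given), compound 3 holds the lowest of the three numbers. The nearest number lies within the scatter: a number 7.5 percentage points lower from compound 2 to compound 3 (within the scatter). The furthest lies beyond it: a number 22.6 percentage points lower from compound 1 to compound 3 (beyond the scatter).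

Compound 4 `NC(=O)C[C@H](NC(=O)CN(c1nc(Cl)nc2[nH]cnc12)C1CC1)C(=O)OCc1ccccc1` differs from compound 3 in one place: carbamoyl in place of isopropyl on a saturated chain carbon, two bonds along the chain from an amide-type nitrogen and a carbonyl carbon. The step at the same place, a number 22.6 percentage points lower from compound 1 to compound 3 (beyond the scatter), ran from hydroxy to isopropyl; the present change takes that isopropyl out again for a carbamoyl carrying one donor and one acceptor. Yet a number 15.1 percentage points lower from compound 1 to compound 2 (beyond the scatter) shows that a donor-bearing chain does not by itself keep the number high, and a number 7.5 percentage points lower from compound 2 to compound 3 (within the scatter) was within the scatter. A modest rise is therefore expected, a number 10.7 percentage points higher from compound 3 to compound 4 (beyond the scatter). Compound 4 is estimated at 16%, range 4% to 32%.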

Compound 4, a percentage reported as activity, at one dose (the size of the read-out at that dose, not a potency): 13.5%
Compound 4: middle estimate off by 2.5 percentage points, on the high side; measured number inside the range.
By their numbers in this assay, from the lowest: compounds 3, 2 and 4 (each within the scatter of the next); then compound 1.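

Carbamoyl at this position cannot be told apart from isopropyl (a number 8.2 percentage points higher from compound 3 to compound 4 (within the scatter)), nor carbamoylmethyl from 1-hydroxyethyl (a number 0.7 percentage points higher from compound 2 to compound 4 (within the scatter)). Only the hydroxy stays clearly apart (a number 14.4 percentage points lower from compound 1 to compound 4 (beyond the scatter)), so among these compounds, the hydrogen-bond donor and acceptor of carbamoyl do not by themselves bring the number back to the hydroxy level. No evidence on why this is so is available.

As far as these compounds go, whether an amine, a carboxylic acid or a longer chain ending in carbamoyl at this position would match the hydroxy remains open.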